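Working notes: the step from compound 1 to compound 4

The compounds below may be only part of what the source reports. "The series", "measured", "known", "first", "only" and "open" are said of these compounds alone.

In an ADME assay on microsomes from liver (Mus musculus) for metabolic stability, read by LC-MS, using NADPH, with a stated time of 60 min, tested at 0.1 uM (a higher number here means that more of the compound is left, a lower number that less of the compound is left), compound 1 (`Fc1ccc(Nc2cc3[nH]c(Nc4cc(N5CCNCC5)ccn4)nc3cn2)cc1C(F)(F)F`) gives 78% as the highest of three numbers. Compound 3 (`C[C@H]1CN(c2ccc(Nc3nc4cnc(Nc5cccc(C(F)(F)F)c5)cc4[nH]3)nc2)CCN1`) stands at 63% and compound 2 (`C[C@@H]1CN(c2ccc(Nc3nc4cnc(Nc5ccc(F)c(C(F)(F)F)c5)cc4[nH]3)nc2)C[C@H](C)O1`) at 6% with both beyond the scatter below compound 1. Compound 4 (`O=C(c1ccnc(Nc2nc3cnc(Nc4ccc(F)c(C(F)(F)F)c4)cc3[nH]2)c1)N1CCN(C2CC2)CC1`) carries (4-cyclopropylpiperazin-1-yl)carbonyl in place of piperazin-1-yl on an aromatic carbon, opposite the ring nitrogen ((4-cyclopropylpiperazin-1-yl)carbonyl in place of piperazin-1-yl on an aromatic carbon). Among the measured compounds shown here, no measured pair isolates this change. A downward step beyond the scatter is expected in this assay. Compound 2 at 6% shows how far a value can sit from compound 1. The estimated step of a number 40 percentage points lower from compound 1 to compound 4 (beyond the scatter) is a clear loss. For compound 4 the expected value is 38% within an estimated range of 12% to 68% for this read-out.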

Compound 4, percent of the compound remaining: 93%
Compound 4: the middle estimate sits 55 percentage points below what was measured, and the stated range ends below it.
By their numbers in this assay, from the lowest: compound 2; then compound 3; then compound 1; then compound 4.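

In this assay the swap of piperazin-1-yl for (4-cyclopropylpiperazin-1-yl)carbonyl gives a number 15 percentage points higher from compound 1 to compound 4 (beyond the scatter), so this place, opposite the ring nitrogen, takes the larger group with no loss. Among the compounds shown here, this is the first single-place change read, and it brings in the carbonyl and the cyclopropyl together. Nothing measured explains the rise.

The compounds shown leave open whether the carbonyl or the cyclopropyl carries the step. They also leave open how a 4-methylpiperazin-1-yl or a morpholin-4-ylcarbonyl group would read at this place.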